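The source may hold more compounds than are shown below. What is called first, only, known or untested is meant among the compounds shown, and "the series" means these compounds.

Three phosphate esters carrying a dithiocarbamate have been measured in a functional assay on MCF7 cells (Homo sapiens) for inhibition, read by MTT assay, with stated times of 18 h and 4 h; a lower number here means a stronger inhibitor, a higher number a weaker inhibitor. Compound 1, `CCCCCCCCCCCCCCCCOP(=O)(O)OCCSC(=S)N1CCCCC1`, gives 29000 nM. Compound 3, `CCCCCCCCOP(=O)(O)OCCSC(=S)N1CCCC1`, gives 53000 nM. Compound 2, `CCCOP(=O)(O)OCCSC(=S)N1CCCCCC1`, gives 74000 nM, which is the highest of the three numbers; its gap to compound 3 lies within the scatter, while its gap to compound 1 lies beyond it, so compound 2 is a weaker inhibitor than compound 1 but cannot be ordered against compound 3.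

Compound 4, `CCCCCCCCCCOP(=O)(O)OCCSC(=S)N1CCCCCC1`, has not yet been measured. It differs from compound 2 in one place: heptyl in place of hydrogen on a saturated chain carbon, three bonds along the chain from an oxygen on an unsaturated carbon. Among the measured compounds, the one with the longest chain, compound 1, has the lowest number, and the one with the shortest chain, compound 2, has the highest. On that basis the expected step is a modest lowering of the number, a 1.9-fold lower number from compound 2 to compound 4 (0.27 log units; within the scatter), possibly still within the scatter. Compound 4 is therefore estimated to give 40000 nM in this assay, with a range from 20000 nM to 80000 nM.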

Compound 4, half-maximal inhibitory concentration: 43300 nM
Beside the measured number, compound 4's estimate is 1.1-fold (0.03 log units) below it, within the range that was stated.
By their numbers in this assay, from the lowest: compounds 1, 4, 3 and 2 (each within the scatter of the next, the first and the last beyond it).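

This is the only pair shown that differs in one place, so it isolates what the chain does while the rest of the molecule stays the same. In this assay heptyl in place of hydrogen, on a saturated chain carbon, three bonds along the chain from an oxygen on an unsaturated carbon, gives a 1.7-fold lower number from compound 2 to compound 4 (0.23 log units; within the scatter) and so does not separate the two compounds at this position. No measurement at hand bears on why these two numbers lie so close together.

Steps among the other compounds cannot be read, since those pairs differ in more than one place. Open on the core of compound 2 is what a longer chain, or an amine or a carboxylic acid at the end of the chain, would do at this position.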